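The compounds below may be only part of what the source reports. "The series", "measured", "known", "first", "only" and "open" are said of these compounds alone.

Measured in a functional assay on NCI-H1975 cells (Homo sapiens) for inhibition, read by CellTiter-Glo, with a stated time of 72 h; on this read-out higher numbers stand for weaker inhibition of growth and lower numbers for stronger inhibition of growth:
compound 1 `C=CC(=O)Nc1cc(Nc2ncc(Cl)c(Nc3ccccc3S(=O)(=O)C(C)C)n2)c(OC)cc1N1CCN(C2CCCCC2)CC1` gives 77 nM
compound 2 `C=CC(=O)Nc1cc(Nc2ncc(C)c(Nc3ccccc3S(=O)(=O)C(C)C)n2)c(OC)cc1N1CCC(N2CCN(C)CC2)CC1` gives 27 nM
compound 3 `C=CC(=O)Nc1cc(Nc2ncc(C)c(Nc3ccccc3S(=O)(=O)C(C)C)n2)c(OC)cc1N1CCN(CC)CC1` gives 43 nM

On these three numbers compound 3 sits between the other two. Its gap to compound 2 and its gap to compound 1 are both within the usual scatter of repeated measurements, so the three measured compounds cannot be ranked against one another on this read-out. Going by the values given here, no two measured compounds differ in a single place, so no single-step comparison is available from the measured set.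

Compound 4 `C=CC(=O)Nc1cc(Nc2nccc(Nc3ccccc3S(=O)(=O)C(C)C)n2)c(OC)cc1N1CCN(CC)CC1` is the next compound. Against compound 3 the change is hydrogen in place of methyl on an aromatic carbon. No measured compound shows this change, so the expectation rests on the change alone rather than on a shown step.

In this assay the step from compound 3 to compound 4 is expected to go toward weaker growth inhibition, by a moderate amount, somewhat beyond the scatter rather than within it. The step this estimate means, a 3.0-fold higher number from compound 3 to compound 4 (0.48 log units; beyond the scatter), is expected to fall beyond the usual scatter in the direction of weaker inhibition. Compound 4 is therefore estimated at 130 nM, with a range from 50 nM to 400 nM.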

Compound 4, concentration for 50% growth inhibition: 190 nM
The estimate for compound 4 lay 1.5-fold (0.16 log units) below the measured number; measured number inside the range.
By their numbers in this assay, from the lowest: compounds 2, 3 and 1 (each within the scatter of the next, the first and the last beyond it); then compound 4.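

In this assay, going by these compounds alone, the exchange of methyl for hydrogen on an aromatic carbon of the six-membered aromatic ring with 2 nitrogen gives a 4.4-fold higher number from compound 3 to compound 4 (0.65 log units; beyond the scatter), the first step that can be read at a single place, and it points toward weaker inhibition of growth. The position, ortho to a large group, two atoms from the ring nitrogen and para to a large group, is therefore not indifferent on this read-out: losing one carbon, with no ring, no hydrogen-bond donor or acceptor and no net charge involved, moves the number beyond the scatter. Nothing available bears on why the number moves.

Whether fluorine, nitrile or trifluoromethyl on this carbon would leave compound 3 near 43 nM or shift the number in either direction is open. Also open, on these data alone, is whether the same exchange of methyl for hydrogen gives a step of similar size alongside the larger groups carried by compound 1 and compound 2.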